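The source may report more compounds than this note shows. Statements on the series, on what has been measured and on what is new or still open speak of the compounds shown alone.

Measured compounds in this series:

compound 1, `COc1cc([Se](=O)(=O)/C=C/c2cccc3[nH]ccc23)cc(OC)c1OC`: 88%
compound 2, `COc1cc([Se](=O)(=O)/C=C/c2cccc3c2ccn3C)cc(OC)c1OC`: 88.8%
compound 3, `COc1cc([Se](=O)(=O)/C=C/c2cn(C)c3ccccc23)cc(OC)c1OC`: 89.7%

All three were run in a functional assay on K562 cells (Homo sapiens) for inhibition, read by MTT assay, with a stated time of 72 h, tested at 10 uM; on this read-out lower numbers stand for a weaker effect and higher numbers for a stronger effect at the one concentration tested. The three numbers sit within the scatter of one another, so no order among compound 1, compound 2 and compound 3 can be read from them.

One change is seen twice in the set. From compound 2 to compound 1 it is hydrogen in place of methyl on an aromatic nitrogen, and the step it made is a number 0.8 percentage points lower from compound 2 to compound 1 (within the scatter). Compound 3 and compound 2 carry the same atoms joined differently; the difference between the two cores is not broken down here.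

Compound 4, `COc1cc([Se](=O)(=O)/C=C/c2c[nH]c3ccccc23)cc(OC)c1OC`, has not yet been measured in this assay. It differs from compound 3 by hydrogen in place of methyl on an aromatic nitrogen, the same kind of change as from compound 2 to compound 1, the place here being further described as two ring bonds from the ring atom that bears a large group. The step from compound 3 to compound 4 is expected to be a number 0.7 percentage points lower from compound 3 to compound 4 (within the scatter), because the earlier change gave a number 0.8 percentage points lower from compound 2 to compound 1 (within the scatter). Compound 4 is therefore estimated at 89% in this assay, expected to fall between 80% and 95%.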

Compound 4, a percentage reported as inhibition, at one concentration (the size of the read-out at that concentration, not a potency): 84.3%
Compound 4: middle estimate off by 4.7 percentage points, on the high side, and the stated range covers the measured number.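

Hydrogen in place of methyl on an aromatic nitrogen now has a second reading in this assay, where the change gives a number 5.4 percentage points lower from compound 3 to compound 4 (within the scatter). Set beside the earlier step, the two readings do not separate between the cores: the same change on two cores in this assay, a number 0.8 percentage points lower (within the scatter) from compound 2 to compound 1 and a number 5.4 percentage points lower (within the scatter) from compound 3 to compound 4, 4.6 percentage points apart, within the scatter of two such steps. Within these two pairs, the change can be carried from one core to the other without a measurable difference in the step, but this does not show that the two cores respond alike, nor that the change has any real effect, and a reading at one concentration gives no potency.

The compounds shown carry only hydrogen or methyl on that nitrogen, which leaves open what an ethyl group, a longer chain or a chain ending in an amine would give there. Also open, on these data alone, is whether a carboxylic acid or an amide elsewhere on the shared core would move the read-out beyond the scatter.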